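This account rests on a few compounds, and the source may have more. Where it says the series, first, only, none or still open, it means among the compounds named here.

In a functional assay on HCC827 cells (Homo sapiens) for inhibition, read by fluorescence, with a stated time of 72 h (on this read-out lower numbers stand for stronger inhibition of growth and higher numbers for weaker inhibition of growth), compound 1 `CCCCCCn1cnc2c(Nc3ccc(O)cc3)nc(N[C@H]3CC[C@H](N)CC3)nc21` gives 24700 nM. Compound 2 `CCCCCCn1cnc2c(Nc3cccc(Cl)c3)nc(N[C@H]3CC[C@H](N)CC3)nc21` gives 10200 nM, the lower of the two numbers and so the stronger growth inhibition measured so far. The next compound, compound 3 `CCCCn1cnc2c(Nc3cccc(Cl)c3)nc(N[C@H]3CC[C@H](N)CC3)nc21`, keeps the 3-chlorophenyl group of compound 2 and changes the chain: hydrogen in place of ethyl on a saturated chain carbon, four bonds along the chain from an aromatic nitrogen. In other words, hydrogen stands in place of ethyl on a saturated chain carbon, four bonds along the chain from an aromatic nitrogen. For the measured compounds named here, only one measured step is available, a 2.4-fold lower number from compound 1 to compound 2 (0.38 log units; beyond the scatter), and it swaps 4-hydroxyphenyl for 3-chlorophenyl and leaves the chain untouched. It therefore gives no direct guide to this change, and the data show no direction for it. No step beyond the usual scatter is expected in this assay, although the uncertainty is wide. This estimate means an expected step of a 1.2-fold higher number from compound 2 to compound 3 (0.07 log units; within the scatter). For compound 3 the estimated value is 12000 nM, with an expected range from 4500 nM to 30000 nM.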

Compound 3, concentration for 50% growth inhibition: 7200 nM
For compound 3 the middle estimate is 1.7-fold (0.22 log units) above the measured one; the measured number falls inside the stated range.
By their numbers in this assay, from the lowest: compounds 3 and 2 (each within the scatter of the next); then compound 1.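

In this assay, for the compounds shown here, replacing the ethyl end of the chain with hydrogen gives a 1.4-fold lower number from compound 2 to compound 3 (0.15 log units; within the scatter), so this is the first sign of how the chain bears on growth inhibition: the read-out does not separate the two chain lengths. Within this pair, the ethyl at this position, four bonds along the chain from an aromatic nitrogen, can be removed without a change that stands clear of the usual scatter. No measurement at hand explains this result.

Still open, as far as these compounds go, is whether a much shorter chain, such as a methyl or ethyl group on the aromatic nitrogen, would give the same result, or whether a chain ending in an amine or a carboxylic acid would shift the number. From the compounds shown here alone, it is also open whether the same shortening would behave alike with the 4-hydroxyphenyl group of compound 1 in place of 3-chlorophenyl.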